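Acetyl on the amino nitrogen of compound 2

The source may hold more compounds than are shown below. What is called first, only, known or untested is meant among the compounds shown, and "the series" means these compounds.

Compound 2 `Nc1cccc(C2=NNC(=O)CC2)c1` gives no number in a functional assay for inhibition, with Homo sapiens as the target; on this read-out higher numbers stand for an effect only at larger amounts of compound and lower numbers for an effect already at smaller amounts. Its reading, > 46.4 ug/mL, is a limit of the assay and not a measured value. This places compound 2 at the limit of > 46.4 ug/mL in this assay, at which 1 of the 2 values shown sits. In this assay compound 1 `CCCC(=O)Nc1ccc(C2=NNC(=O)CC2)cc1` gives a measured value of 1.44 ug/mL. For the measured compounds named here, no measured step links these two compounds, and the comparison ends with a number for one and a limit for the other.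

Compound 3 `CC(=O)Nc1cccc(C2=NNC(=O)CC2)c1` turns the amino group of compound 2 into an acetamido group (acetyl in place of hydrogen on a nitrogen on an aromatic ring). Compound 3 thus carries an amide on a nitrogen on an aromatic ring. The only support for a direction is compound 1, which also carries such an amide and reads 1.44 ug/mL. Compound 1 differs from compound 3 in more than this one place, so that support is weak. A shift towards effect at smaller amounts is expected, modest in size, and a second reading at the limit remains quite possible. The expected change is an at least 2.3-fold lower number from compound 2 to compound 3 (0.36 log units; beyond the scatter). For compound 3 the estimated value is 20 ug/mL, with an expected range from 4 ug/mL to 60 ug/mL.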

Compound 3, half-maximal effective concentration: > 46.4 ug/mL
Compound 3 ended at the assay's limit; the forecaster's own chance of this, stated with the estimate: 45%; at least 2.3-fold (0.36 log units) between middle value and limit.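

In this assay compound 3 reads > 46.4 ug/mL, a limit of the assay and not a number. Compound 2 stands at the same limit, so no step can be read between compound 2 and compound 3: the limit of > 46.4 ug/mL in this assay, at which 2 of the 3 values shown sit.

Going by these compounds, whether acetyl in place of hydrogen on this nitrogen shifts the read-out at all stays open.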